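A few compounds are considered here, and "the series" means these few. Any claim that something is new, unique, unknown or untested is made for them only; others in the source may bear on it.

Of the compounds shown here, two have numbers so far. Compound 1 `CN(CCCNS(=O)(=O)c1cc(C(F)(F)F)cc(C(F)(F)F)c1)Cc1ccccc1` gives 46000 nM in a functional assay on Capan-2 cells (Homo sapiens) for inhibition, read by MTT assay, with a stated time of 72 h; on this read-out lower numbers stand for stronger inhibition of growth and higher numbers for weaker inhibition of growth. Compound 2 `O=S(=O)(NCCCNCc1ccc(-c2ccccc2)cc1)c1cc(C(F)(F)F)cc(C(F)(F)F)c1` gives 2200 nM in this assay, the lower of the two numbers; the gap to compound 1 lies beyond the scatter. Compound 3 `COc1ccc(CNCCCNS(=O)(=O)c2cc(C(F)(F)F)cc(C(F)(F)F)c2)cc1` carries methoxy in place of phenyl on an aromatic carbon, methoxy in place of phenyl on an aromatic carbon. Going by the values given here, no measured pair covers this change. A moderate rise in the number is expected, so compound 3 is estimated at 8000 nM, within 3000 nM to 25000 nM, a step of a 3.6-fold higher number from compound 2 to compound 3 (0.56 log units; beyond the scatter).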

Compound 3, concentration for 50% growth inhibition: 2400 nM
The estimate for compound 3 lay 3.3-fold (0.52 log units) above the measured number; the whole stated range lies above it.
By their numbers in this assay, from the lowest: compounds 2 and 3 (each within the scatter of the next); then compound 1.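

In this assay methoxy in place of phenyl on an aromatic carbon, para to a large group, gives a 1.1-fold higher number from compound 2 to compound 3 (0.04 log units; within the scatter) and so shows that this position accepts a group of 2 heavy atoms as well as one of 6 heavy atoms. (4-methoxybenzyl)amino in place of benzyl(methyl)amino gives a 19-fold lower number from compound 1 to compound 3 (1.28 log units; beyond the scatter) and is the large step among these compounds. Still open, as far as these compounds go, is whether a hydroxyl group, a chlorine atom or a carboxylic acid at this position would read the same, and whether the methyl group or the methoxy group carries the large step. Nothing measured here gives a reason for either step.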